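The source may hold more compounds than are shown below. What is called first, only, known or untested is meant among the compounds shown, and "the series" means these compounds.

Three compounds share one core and differ only in the group carried on the amine nitrogen of the outer ring. Compound 1 `COc1cc(N)c(Cl)cc1C(=O)NC1CCN(CC2CCN(CC(C)CN)CC2)CC1` gives 14.3 nM in an assay on striatum for inhibition of 5-hydroxytryptamine receptor 4 (Cavia porcellus), read by radioligand binding; a lower number here means a stronger inhibitor, a higher number a weaker inhibitor. Compound 2 `COc1cc(N)c(Cl)cc1C(=O)NC1CCN(CC2CCN(C(=O)CN)CC2)CC1` gives 9.3 nM, and compound 3 `COc1cc(N)c(Cl)cc1C(=O)NC1CCN(CC2CCN(C(=O)CCCCN)CC2)CC1` gives 3.91 nM. Compound 3 has the lowest number of the three: the nearest is compound 2, with a 2.4-fold lower number from compound 2 to compound 3 (0.38 log units; beyond the scatter), and the furthest is compound 1, with a 3.7-fold lower number from compound 1 to compound 3 (0.56 log units; beyond the scatter). Between the other two, a 1.5-fold lower number from compound 1 to compound 2 (0.19 log units; within the scatter).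

Compound 4 `COc1cc(N)c(Cl)cc1C(=O)NC1CCN(CC2CCN(CCCNS(C)(=O)=O)CC2)CC1` is the next step from compound 3: 3-(methanesulfonamido)propyl in place of (4-aminobutyl)carbonyl on an amine nitrogen in a ring. All three measured steps bear on this change. Each of them also exchanged the group on the same ring nitrogen, and each stayed modest in size. Yet every one of compounds 1, 2 and 3 carries a chain ending in an amino group, while compound 4 instead ends in a methanesulfonamido group, so the measured steps only loosely guide the expectation. Compound 4 is therefore expected to move back toward a higher number, with a 3.8-fold higher number from compound 3 to compound 4 (0.58 log units; beyond the scatter). The estimate for compound 4 in this assay is 15 nM, in a range from 5 nM to 45 nM.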

Compound 4, half-maximal inhibitory concentration: 21.1 nM
Estimate against measurement, compound 4: 1.4-fold (0.15 log units) below; measured number inside the range.
By their numbers in this assay, from the lowest: compound 3; then compounds 2, 1 and 4 (each within the scatter of the next, the first and the last beyond it).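

In this assay, compound 4 shows that a chain ending in a methanesulfonamido group, rather than an amino group, can sit on this amine nitrogen in a ring, but the change from (4-aminobutyl)carbonyl comes with a 5.4-fold higher number from compound 3 to compound 4 (0.73 log units; beyond the scatter) and is beyond the scatter. The number also rises with a 2.3-fold higher number from compound 2 to compound 4 (0.36 log units; beyond the scatter), while a 1.5-fold higher number from compound 1 to compound 4 (0.17 log units; within the scatter) stays within the scatter, so compound 4 sits level with compound 1, the other compound without a carbonyl on this nitrogen, though compound 2 goes against any simple carbonyl pattern since it too lies within the scatter of compound 1. No measurement shown here explains these differences.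

Compound 4 differs from compound 3 in both the chain ending and the carbonyl, so the compounds shown leave open which of the two accounts for the step. A 3-aminopropyl group on this nitrogen would test the carbonyl alone, and a carbonyl-linked chain ending in methanesulfonamido would test the ending alone, while a chain ending in a carboxylic acid would show how far this position accepts other endings.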